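Moving the methyl on the benzyl ether of compound 3

This account rests on a few compounds, and the source may have more. Where it says the series, first, only, none or still open, it means among the compounds named here.

Measured so far:
compound 1 `Cc1cc(OCc2cccc(-c3c(C)cccc3C)c2)ncc1CCC(=O)O` gives 130 nM
compound 2 `Cc1cccc(C)c1-c1cccc(COc2ccc(CCC(=O)O)c(C)n2)c1` gives 1100 nM
compound 3 `CCOC(CC(=O)O)c1ccc(OCc2ccccc2C)cc1` gives 79 nM

In a functional assay on CHO cells for agonist activity at Free fatty acid receptor 1 (Rattus norvegicus), read by calcium flux (a lower number here means that less compound is needed, a higher number that more compound is needed for the effect), compound 3 has the lowest of the three numbers; compound 1 lies within the scatter of it, and compound 2 lies beyond it. The next compound, compound 4 `CCOC(CC(=O)O)c1ccc(OCc2cccc(C)c2)cc1`, keeps every atom of compound 3 and differs only in how they are joined: 3-methylphenyl in place of 2-methylphenyl on a saturated chain carbon bound to an oxygen on an aromatic ring. Within the data shown here, no step between measured compounds of this kind is available, so the size of this change is not known from the set. Such a shift of a methyl is expected to move the number little, and in no settled direction. The estimate for compound 4 is 120 nM (range 40 nM to 400 nM), a step of a 1.5-fold higher number from compound 3 to compound 4 (0.18 log units; within the scatter) that is expected to stay near the scatter.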

Compound 4, half-maximal effective concentration: 78 nM
Compound 4: the middle estimate sits 1.5-fold (0.19 log units) above what was measured; low and high end bracket the measured number.
By their numbers in this assay, from the lowest: compounds 4, 3 and 1 (each within the scatter of the next); then compound 2.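

In this assay, 3-methylphenyl in place of 2-methylphenyl on a saturated chain carbon bound to an oxygen on an aromatic ring gives a 1.0-fold lower number from compound 3 to compound 4 (0.01 log units; within the scatter) and so stays within the scatter. Among these compounds, this is the first step in the set that isolates this position, and it shows that the number holds with the methyl in either of these two arrangements. No measured evidence here explains this result.

The compounds shown leave open whether a trifluoromethyl or an amine in place of the methyl would also hold the number. They also leave open what removing the methyl altogether would do.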